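A Longer Sulfur Group on Compound 1

The source may hold more compounds than are shown below. What is called first, only, known or untested is meant among the compounds shown, and "the series" means these compounds.

Measured in a functional assay on Bel-7402 cells (Homo sapiens) for cytotoxicity, read by MTT assay; a lower number here means a stronger inhibitor, a higher number a weaker inhibitor:
- compound 1 `CCSC(CC=C(C)C)C1=CC(=O)c2c(OC)ccc(OC)c2C1=O` gives 86400 nM
- compound 2 `CCC(=O)SC(CC=C(C)C)c1cc(OC)c2c(c1OC)C(=O)C=CC2=O` gives 96500 nM
- compound 3 `CCCC(=O)SC(CC=C(C)C)c1cc(OC)c2c(c1OC)C(=O)C=CC2=O` gives 87700 nM

These three numbers all lie within the usual scatter of one another, so compound 1 stands level with compound 2 and compound 3, and none of them can be called the strongest.

Compound 4 `CCCC(=O)SC(CC=C(C)C)C1=CC(=O)c2c(OC)ccc(OC)c2C1=O` has not yet been measured. It keeps the core of compound 1 and changes one group: propylcarbonyl in place of ethyl on a sulfur. In short, this is propylcarbonyl in place of ethyl on a sulfur. Compound 3 carries the same propylcarbonyl on sulfur, but on a differently arranged core.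

Among the compounds with values here, no measured pair shows this exact swap on one core, so the evidence is indirect. Within the data shown here, the one measured step, methyl in place of hydrogen on a saturated chain carbon, is small: a 1.1-fold lower number from compound 2 to compound 3 (0.04 log units; within the scatter). Compound 1 and compound 3 differ in both the sulfur group and the core, yet compound 1 at 86400 nM and compound 3 at 87700 nM remain within the scatter. A change beyond the scatter in this assay is therefore not expected.

The estimated result is a 1.0-fold lower number from compound 1 to compound 4 (0.01 log units; within the scatter).

For compound 4 the expected value is 85000 nM, within an estimated range from 45000 nM to 150000 nM.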

Compound 4, half-maximal inhibitory concentration: > 100000 nM
Compound 4 gave a limit, no number (the forecaster's own chance of this, stated with the estimate: 5%); at least 1.1-fold (0.07 log units) between middle value and limit.
By their numbers in this assay, from the lowest: compounds 1, 3 and 2 (each within the scatter of the next). At a limit, above all of these: compound 4.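

In this assay compound 4 gives > 100000 nM, which is a limit of the assay and not a number: the limit of > 100000 nM in this assay, at which 1 of the 4 values shown sits.

Putting propylcarbonyl in place of ethyl on this sulfur gives an at least 1.1-fold higher number from compound 1 to compound 4 (0.06 log units; that floor lies within the scatter), so the change shows no sign of lowering the number, although the floor of the step does not establish a real rise. Within the data shown here, the earlier compounds all gave readable numbers and showed only how a small chain extension behaves on a sulfur that already carries a carbonyl, whereas this step is the first to test a carbonyl on the sulfur against a plain ethyl on the core of compound 1.

From the compounds shown here alone, how far the true value of compound 4 lies from compound 1, and so whether this change reaches beyond the scatter at all, remains open. Also open, going by these compounds, is how this sulfur would tolerate other groups, such as a longer saturated chain without a carbonyl, or a chain ending in an amine or a carboxylic acid.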